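The source may hold more compounds than are shown below. What is called first, only, known or untested is meant among the compounds shown, and "the series" means these compounds.

Measured compounds:
compound 1 `O=C(Nc1ccccc1Br)C(Cl)Cl` — 38200 nM
compound 2 `O=C(Nc1ccccc1NC(=O)C(Cl)Cl)C(Cl)Cl` — "not determined" (no result reported)
compound 3 `O=C(Nc1cccc(F)c1)C(Cl)Cl` — "not determined" (no result reported)

Going by the values given here, in a functional assay on Bel-7402 cells (Homo sapiens) for antiproliferative activity, read by MTT assay, with a stated time of 72 h (a lower number here means a stronger inhibitor, a higher number a weaker inhibitor), compound 1 gives 38200 nM, the only number in this set. Compound 2 carries no result in this assay, and compound 3 likewise has no result there, so compound 3 stands without a number against which a step could be measured. Compound 4 `N#Cc1cccc(NC(=O)C(Cl)Cl)c1` differs from compound 3 by one change, (cyano in place of fluoro on an aromatic carbon), a cyano in place of fluoro on an aromatic carbon. Among the compounds with values here, no step between measured compounds is available, so no direction or size of change in this assay can be inferred from the data, and the shared core is only anchored by compound 1. Compound 4 is therefore expected to lie near 40000 nM, in a range from 8000 nM to 200000 nM.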

Compound 4, half-maximal inhibitory concentration: 48400 nM
Compound 4: the middle estimate sits 1.2-fold (0.08 log units) below what was measured; the measured number falls inside the stated range.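

Going by these compounds alone, compound 3 has no single number in this assay, so no step to compound 4 can be read. The compounds shown leave open how cyano compares with fluoro on that aromatic carbon. No evidence at hand bears on this result.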